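The source may report more compounds than this note shows. Statements on the series, on what has been measured and on what is new or still open speak of the compounds shown alone.

Three related compounds have been measured in a functional assay on MCF7 cells (Homo sapiens) for inhibition (a higher number here means a weaker inhibitor, a lower number a stronger inhibitor), and their numbers lie fairly close together. Compound 1 (`C=C/C(C)=C/[C@@]1(C)SC(=O)C=C1O`) gives 40.3 ug/mL while compound 2 (`CCCCCCCC[C@@]1(C)SC(O)=C(C)C1=O`) gives 16.5 ug/mL and compound 3 (`CCCCCC[C@@]1(C)SC(=O)C=C1OCC(=O)NCCCBr`) gives 6.7 ug/mL on the same scale. Compound 2 therefore stands in the middle of the three. Its number is lower than that of compound 1 and higher than that of compound 3, by similar margins that both lie beyond the usual scatter.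

The next compound to be measured is compound 4 (`CCCCCCCC[C@@]1(C)SC(O)=C(C(=O)C(F)(F)F)C1=O`), which differs from compound 2 in one place. The change is (trifluoromethyl)carbonyl in place of methyl on a double-bonded ring carbon and it places (trifluoromethyl)carbonyl in place of methyl on a double-bonded ring carbon, next to the ring atom that bears a hydroxy group.

Within the data shown here, no measured pair differs by this change alone, which makes any forecast uncertain. The measured span runs only from compound 3 at 6.7 ug/mL to compound 1 at 40.3 ug/mL and this argues for expecting a modest shift. In this assay the expected result is a small move towards stronger inhibition, estimated as a 1.4-fold lower number from compound 2 to compound 4 (0.14 log units; within the scatter) and thus no step beyond the usual scatter. For compound 4 the estimated value is 12 ug/mL (expected range 4 ug/mL to 35 ug/mL).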

Compound 4, half-maximal inhibitory concentration: 14.7 ug/mL
Beside the measured number, compound 4's estimate is 1.2-fold (0.09 log units) below it, and the stated range covers the measured number.
By their numbers in this assay, from the lowest: compound 3; then compounds 4 and 2 (each within the scatter of the next); then compound 1.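

Among these compounds, this is the first pair here that differs in one place only, so it gives the first direct reading of the double-bonded ring carbon next to the ring atom that bears a hydroxy group. In this assay, putting (trifluoromethyl)carbonyl in place of methyl gives a 1.1-fold lower number from compound 2 to compound 4 (0.05 log units; within the scatter) and, since this step lies within the usual scatter, the two compounds cannot be told apart even though the entering group is much larger and carries a hydrogen-bond acceptor that methyl lacks. Nothing measured here bears on why the number stays within the scatter after so large an exchange.

The compounds shown do not reveal how far this tolerance extends, since a single exchange cannot show whether an amine, a carboxylic acid, a plain hydrogen or a longer carbon chain on this ring carbon would read the same way. They also leave open whether (trifluoromethyl)carbonyl would behave alike when the group of 8 heavy atoms shared by compound 2 and compound 4 is replaced by a shorter chain or by one ending in a phenyl ring.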